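A Further Step Along the Chain to Compound 3

This account rests on a few compounds, and the source may have more. Where it says the series, first, only, none or still open, it means among the compounds named here.

In a functional assay on SH-SY5Y cells (Homo sapiens) for cytotoxicity, read by MTT assay, with a stated time of 72 h (a lower number here means a stronger inhibitor, a higher number a weaker inhibitor), compound 1 (`CC(C)[S+]([O-])CCCCN=C=S`) gives 9420 nM, and compound 2 (`CC(C)[S+]([O-])CCCCCN=C=S`) gives 8620 nM. These two values lie within the scatter of each other, so compound 2 cannot be separated from compound 1 on the numbers available. Compound 3 (`CC(C)[S+]([O-])CCCCCCN=C=S`) differs from compound 2 in one place: a group of 4 heavy atoms (2 carbon, 1 nitrogen, 1 sulfur; no ring) in place of a group of 3 heavy atoms (1 carbon, 1 nitrogen, 1 sulfur; no ring), on a saturated chain carbon, five bonds along the chain from a sulfur. Going by the values given here, the one measured step that bears on this change is the like replacement four bonds along the chain from a sulfur, a 1.1-fold lower number from compound 1 to compound 2 (0.04 log units; within the scatter). Among the compounds with values here, with only that small step to go on, no change beyond the scatter is expected in this assay, although a single step is thin evidence. The expected step is a 1.1-fold lower number from compound 2 to compound 3 (0.06 log units; within the scatter). Compound 3 is estimated at 7500 nM, with an expected range from 3800 nM to 13000 nM.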

Compound 3, half-maximal inhibitory concentration: 7820 nM
Compound 3: the middle estimate sits 1.0-fold (0.02 log units) below what was measured; the range from low to high includes it.
By their numbers in this assay, from the lowest: compounds 3, 2 and 1 (each within the scatter of the next).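

In this assay the same kind of replacement, now five bonds along the chain from a sulfur, gives a 1.1-fold lower number from compound 2 to compound 3 (0.04 log units; within the scatter). This second step joins a 1.1-fold lower number from compound 1 to compound 2 (0.04 log units; within the scatter), and neither lies beyond the scatter, so at this place too the group of 4 heavy atoms cannot be told from the group of 3 heavy atoms, and compound 1, compound 2 and compound 3 form a series without a resolved trend. No evidence is at hand that speaks to this result.

Going by these compounds, whether a longer chain would give a step beyond the scatter remains open. Also open is how an amine or a carboxylic acid would read in place of the group that enters here, since all the compounds shown keep the same kind of group at this place.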